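This account rests on a few compounds, and the source may have more. Where it says the series, first, only, none or still open, it means among the compounds named here.

Of the compounds shown here, three have been measured so far in a physicochemical assay for solubility, read by HPLC, using the shake flask method, measured as kinetic solubility, with a stated time of 20 h, at pH 6.5, tested at 200 uM (a lower number here means a less soluble compound, a higher number a more soluble compound), and they frame the question. Compound 1 (`O=S(=O)(NCC1COC1)c1cccc(-c2ccc3nccc(-c4ccncc4)c3n2)c1`) gives 20000 nM and sits within the scatter of compound 2 (`O=S(=O)(c1cccc(Nc2ccc3nccc(-c4ccncc4)c3n2)c1)N1CCCCC1`), which gives 15000 nM in the same test. Compound 3 (`CS(=O)(=O)Nc1ccc2nccc(-c3ccncc3)c2n1`) gives 90000 nM, and the gap up from compound 1 lies beyond the scatter.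

Compound 4 (`NS(=O)(=O)c1cccc(-c2ccc3nccc(-c4ccncc4)c3n2)c1`) has not yet been measured. Its difference from compound 1 is hydrogen in place of (oxetan-3-yl)methyl on a sulfonamide nitrogen as hydrogen takes the place of (oxetan-3-yl)methyl on a sulfonamide nitrogen. Going by the values given here, no measured pair shows this change alone, so its size can only be judged indirectly. Compound 1 at 20000 nM and compound 2 at 15000 nM lie close together although their structures differ, and this offers no sign of a large move. A small fall is expected, with a 1.7-fold lower number from compound 1 to compound 4 (0.22 log units; within the scatter) estimated to stay within the scatter. For compound 4 the estimate is 12000 nM with an expected range from 4000 nM to 40000 nM.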

Compound 4, solubility: < 5000 nM
Compound 4 was reported as a limit (the forecaster's own chance of this, stated with the estimate: 5%); at least 2.4-fold (0.38 log units) between middle value and limit.
By their numbers in this assay, from the lowest: compounds 2 and 1 (each within the scatter of the next); then compound 3. At a limit, below all of these: compound 4.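

In this assay compound 4 is reported only as a limit, < 5000 nM. Replacing (oxetan-3-yl)methyl with hydrogen on the sulfonamide nitrogen gives an at least 4.0-fold lower number from compound 1 to compound 4 (0.60 log units; beyond the scatter), the first step shown in which one change alone moves the number beyond the scatter, so the group on this nitrogen is not interchangeable with hydrogen in this test. How far the number falls cannot be read, because the step ends at a limit: the limit of < 5000 nM in this assay, at which 1 of the 4 values shown sits.

The compounds shown leave open whether the four-membered ring of (oxetan-3-yl)methyl is needed, or whether a plain ethyl or a longer open chain on the same nitrogen would hold the number of compound 1. They also leave open how a substituent carrying an amine or a carboxylic acid would read at this place.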